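The source may report more compounds than this note shows. Statements on the series, on what has been measured and on what is new or still open speak of the compounds shown alone.

Measured compounds in an ADME assay on 2209-23 cells (Homo sapiens) for cytotoxicity, read by WST assay and thymidine incorporation; on this read-out lower numbers stand for higher toxicity in this test and higher numbers for lower toxicity in this test:

Compound 1 `CC(C)(C)[C@H]1C(O)=C(C2=C(C(N)=O)S(=O)(=O)c3cc(NS(C)(=O)=O)ccc3N2)C(=O)N1Cc1ccc(F)cc1` gives a limit of the assay, > 50000 nM.
Compound 2 `CC(C)(C)[C@H]1C(O)=C(C2=CS(=O)(=O)c3cc(NS(C)(=O)=O)ccc3N2)C(=O)N1Cc1ccc(F)c(Cl)c1` gives a limit of the assay, > 50000 nM.
Compound 3 `CC(C)(C)[C@H]1C(O)=C(C2=CS(=O)(=O)c3cc(NS(C)(=O)=O)ccc3N2)C(=O)N1Cc1ccccc1` gives a limit of the assay, > 50000 nM.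

For the measured compounds named here, compound 1 therefore stands at the limit of this assay and not at a number; every value so far sits there, as the limit of > 50000 nM in this assay, at which 3 of the 3 values shown sit, shows. Going by the values given here, the one single-point step among the measured compounds, a step that the two limits leave unreadable from compound 2 to compound 3, is left unreadable by the two limits, so it gives no scale for any change.

The next compound, compound 4 `CC1=C(C2=C(O)[C@H](C(C)(C)C)N(Cc3ccc(F)cc3)C2=O)Nc2ccc(NS(C)(=O)=O)cc2S1(=O)=O`, is derived from compound 1 by one change, (methyl in place of carbamoyl on a double-bonded ring carbon). Among the compounds with values here, no measured step touches this position of the core of compound 1, and the only measured step is unreadable, so there is nothing to read a direction or a size from. All that the data show is that three compounds of the series sit at the limit in this assay.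

On that basis compound 4 is expected to sit at the limit as well, with an estimated value of 80000 nM and a range from 30000 nM to 250000 nM. The expected step from compound 1, a step that the limit leaves unreadable from compound 1 to compound 4, is not expected to be readable beyond the limit.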

Compound 4, half-maximal cytotoxic concentration: > 50000 nM
Compound 4 gave a limit, no number; the forecaster's own chance of this, stated with the estimate: 85%; the middle value is on the limit's open side.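

Compound 1 and compound 4 both give only a limit in this assay, so the change from carbamoyl to methyl yields no readable step. The compounds shown leave open how far any of them lies from that limit, and whether any change on the shared core would give a number at all: the limit of > 50000 nM in this assay, at which 4 of the 4 values shown sit.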